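A few compounds are considered here, and "the series" means these few. Any claim that something is new, unique, unknown or untested is made for them only; others in the source may bear on it.

Working notes on the series. In a functional assay on the whole organism for inhibition, with Rattus norvegicus as the target (on this read-out higher numbers stand for an effect only at larger amounts of compound and lower numbers for an effect already at smaller amounts), compound 1 `CC(C)c1ccc(OC(Cc2ccccc2)C(=O)O)cc1` gives 50 mg/kg. Compound 2 `CC(C)c1ccc(OC(Cc2ccc(Cl)cc2)C(=O)O)cc1` gives 10 mg/kg, the lower of the two actual numbers in this set. Compound 3 `Cc1ccc(CC(Oc2ccc(C(C)C)cc2)C(=O)O)cc1` gives < 50 mg/kg, which is a limit and not a number.

Still unmeasured is compound 4 `O=C(O)C(Cc1ccc(Cl)cc1)Oc1ccccc1`, which departs from compound 2 at one place: hydrogen in place of isopropyl on an aromatic carbon. For the measured compounds named here, no measured step changes that place, so the evidence is only indirect. Going by the values given here, the one readable step is a 5.0-fold lower number from compound 1 to compound 2 (0.70 log units; beyond the scatter), where a group replaces hydrogen elsewhere on the molecule. The other step, a number no higher from compound 1 to compound 3 (the limit leaves the size open), gives no size.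

From compound 2 and that single step, a change of similar size is a reasonable guess, with a higher number more likely than a lower one. The expected outcome is a 3.0-fold higher number from compound 2 to compound 4 (0.48 log units; beyond the scatter). For compound 4 the estimated value is 30 mg/kg, with an expected range of 10 mg/kg to 100 mg/kg.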

Compound 4, dose for half-maximal effect: > 25 mg/kg
Compound 4 gave a limit, no number; the forecaster's own chance of this, stated with the estimate: 20%; the middle value is on the limit's open side.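

For the compounds shown here, this is the first step to touch the place para to a large group; the earlier steps changed only hydrogen, chloro or methyl elsewhere on the molecule. In this assay hydrogen in place of isopropyl on an aromatic carbon gives an at least 2.5-fold higher number from compound 2 to compound 4 (0.39 log units; beyond the scatter) and so, with the chloro group kept, isopropyl at this place goes with an effect at smaller amounts of compound than hydrogen does. Compound 4 holds a limit and not a number, so the full size of this step stays open: the limit of > 25 mg/kg in this assay, at which 1 of the 4 values shown sits.

The compounds shown do not tell whether a methoxy group, an amine or a longer chain at this place would match isopropyl. They also leave open whether the step from isopropyl to hydrogen has a similar size without the chloro group.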